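Nitro Swap at the Assay Limit

A few compounds are considered here, and "the series" means these few. Any claim that something is new, unique, unknown or untested is made for them only; others in the source may bear on it.

Measured in a functional assay on B16 cells (Mus musculus) for antiproliferative activity, read by MTT assay, with a stated time of 72 h; on this read-out lower numbers stand for stronger inhibition and higher numbers for weaker inhibition:
- compound 1 `COc1cc(/C(=C/c2ccccc2)C(C)O)cc(OC)c1OC`: > 100000 nM (a limit)
- compound 2 `COc1cc(/C(=C/c2ccc([N+](=O)[O-])cc2)C(C)O)cc(OC)c1OC`: > 100000 nM (a limit)

Compound 1 gives > 100000 nM, which is a limit and not a number. Among the measured compounds shown here, it therefore has no exact starting value, and the same is true of the only other compound measured: the limit of > 100000 nM in this assay, at which 2 of the 2 values shown sit.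

Compound 3 `COc1cc(/C(=C/c2cccc([N+](=O)[O-])c2)C(C)O)cc(OC)c1OC` keeps the core of compound 1 and carries one change: nitro in place of hydrogen on an aromatic carbon. The new nitro sits on an aromatic carbon, meta to a large group.

For the measured compounds named here, one measured step bears on this, as it is also nitro in place of hydrogen on an aromatic carbon: a step that the two limits leave unreadable from compound 1 to compound 2. Its size cannot be read, so it gives no basis for expecting a step of any particular size or direction in this assay. Going by the values given here, it shows only that this swap once left the value at the limit, and the same outcome is expected here, most likely reported again as a limit.

The expected value for compound 3 is 100000 nM, with an estimated range of 30000 nM to 200000 nM. The estimate therefore means a number no higher from compound 1 to compound 3 (the limit leaves the size open).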

Compound 3, half-maximal inhibitory concentration: > 100000 nM
Compound 3: no number, only a limit; the forecaster's own chance of this, stated with the estimate: 75%; the middle value sits exactly at the limit.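

Compound 3 also gives a limit and not a number, so neither its step from compound 1 nor the step from compound 1 to compound 2 can be read: the limit of > 100000 nM in this assay, at which 3 of the 3 values shown sit.

The compounds shown leave open whether nitro in place of hydrogen on an aromatic carbon changes activity at all in this assay, and what exact number any of them would have.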